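A few compounds are considered here, and "the series" means these few. Any claim that something is new, unique, unknown or untested is made for them only; others in the source may bear on it.

Measured in a functional assay on the whole organism (Abdomen, strain ddY) for inhibition, with Mus musculus as the target, with stated times of 30 min and 20 min; a lower number here means that less compound is needed, a higher number that more compound is needed for the effect:

Compound 1 `CCOc1c(NC)cnn(C)c1=O`: 55 mg/kg
Compound 2 `CCCNc1cnn(C)c(=O)c1OCC`: 72 mg/kg

Compound 2, at 72 mg/kg, cannot be told apart from compound 1 on these numbers. The record shows a 1.3-fold higher number from compound 1 to compound 2 (0.12 log units; within the scatter), so the two compounds stand together and neither leads.

Compound 3 `CCOc1c(Nc2ccccc2)cnn(C)c1=O` is the next to be considered, and it departs from compound 2 on a nitrogen on an aromatic ring, where phenyl stands in place of propyl: phenyl in place of propyl on a nitrogen on an aromatic ring. For the measured compounds named here, only one measured step bears on this change. That step, a 1.3-fold higher number from compound 1 to compound 2 (0.12 log units; within the scatter), lengthened the chain on the same nitrogen and did not move the number beyond the scatter. Going by the values given here, it is weak guidance, since no measured compound carries a ring on that nitrogen, and a change from a chain to a ring has not been tested here. With no measured sign of a direction, no step beyond the scatter is expected, though the range must stay wide. The expected size is a 1.0-fold higher number from compound 2 to compound 3 (0.02 log units; within the scatter). For compound 3 the estimated value in this assay is 75 mg/kg, with an expected range from 30 mg/kg to 190 mg/kg.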

Compound 3, dose for half-maximal effect: 36 mg/kg
Compound 3: middle estimate off by 2.1-fold (0.32 log units), on the high side, and the stated range covers the measured number.
By their numbers in this assay, from the lowest: compounds 3, 1 and 2 (each within the scatter of the next).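

In this assay, for the compounds shown here, the nitrogen on an aromatic ring proves able to carry a six-membered aromatic ring of carbon only as well as a saturated chain, something the earlier compounds, with chains alone, could not show: phenyl in place of propyl gives a 2.0-fold lower number from compound 2 to compound 3 (0.30 log units; within the scatter) and phenyl in place of methyl gives a 1.5-fold lower number from compound 1 to compound 3 (0.18 log units; within the scatter) on the same shared core. Methyl, propyl and phenyl on this nitrogen therefore cannot be separated on these numbers, so neither the size of the group nor the change from chain to ring has yet shown a measurable effect at this position. Nothing on hand offers an explanation for this result.

The compounds shown leave open whether a group on this nitrogen can move the number beyond the scatter at all, and a benzyl group, a cyclohexyl ring or a phenyl ring bearing chlorine or a methoxy group would each put that to the test. They also leave open whether an amine or a carboxylic acid at the end of a longer chain on this nitrogen would behave as propyl does.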